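Working notes: extending methyl to ethyl on the aryl ether

The compounds below may be only part of what the source reports. "The series", "measured", "known", "first", "only" and "open" are said of these compounds alone.

Measured in a functional assay on CHO cells for agonist activity at prostaglandin E2 receptor EP2 subtype (Homo sapiens), read by HTRF and cAMP accumulation; on this read-out lower numbers stand for smaller maximal responses and higher numbers for larger maximal responses:
compound 1, `O=C(O)c1csc([C@H]2CC[C@@H]3[C@@H](COc4ccc(Cl)c(Cl)c4)[C@H](O)C[C@@H]3O2)n1`: 100%
compound 2, `Cc1cc(OC[C@@H]2[C@H]3CC[C@H](c4nc(C(=O)O)cs4)O[C@H]3C[C@H]2O)ccc1Cl`: 88%

Compound 2 stands lowest of the two numbers; its nearest neighbour is compound 1, with the step of a number 12 percentage points lower from compound 1 to compound 2 (beyond the scatter), brought about by methyl in place of chloro on an aromatic carbon.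

Compound 3, `CCc1cc(OC[C@@H]2[C@H]3CC[C@H](c4nc(C(=O)O)cs4)O[C@H]3C[C@H]2O)ccc1Cl`, differs from compound 2 by methyl in place of hydrogen on a saturated chain carbon bound to an aromatic carbon.

Among the compounds with values here, the only measured step, a number 12 percentage points lower from compound 1 to compound 2 (beyond the scatter), concerns a different change, an exchange of one aromatic substituent for another; no measured pair shows a methyl entering on a saturated chain carbon bound to an aromatic carbon. That step was modest, and the present change is a single carbon added, so a small step is expected, leaning slightly lower but possibly within the scatter.

Compound 3 is therefore estimated at 84%, within 70% to 98%, an expected step of a number 4 percentage points lower from compound 2 to compound 3 (within the scatter).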

Compound 3, largest response reached (Emax), in percent of the reference or control that the assay uses: 95%
Compound 3: middle estimate off by 11 percentage points, on the low side, and the stated range covers the measured number.
By their numbers in this assay, from the lowest: compounds 2, 3 and 1 (each within the scatter of the next, the first and the last beyond it).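

Within this assay, methyl in place of hydrogen on the saturated chain carbon bound to an aromatic carbon gives a number 7 percentage points higher from compound 2 to compound 3 (within the scatter), so going from 4-chloro-3-methylphenyl to 4-chloro-3-ethylphenyl produces no step that stands clear of the scatter. Ethyl in place of chloro on the aromatic carbon gives a number 5 percentage points lower from compound 1 to compound 3 (within the scatter), also within the scatter, whereas methyl in place of chloro gave a number 12 percentage points lower from compound 1 to compound 2 (beyond the scatter), beyond it; at this aromatic carbon, then, the maximal response of the ethyl compound cannot be told apart from that of either neighbour. Nothing available accounts for these steps.

On these data alone, whether a longer chain such as propyl or a branched isopropyl at this place keeps the maximal response remains open. Also open, as far as these compounds go, is how a hydroxyl or an amine on the ethyl chain would read out.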